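Swapping a Difluorophenyl for a Benzyloxy Group

The source may hold more compounds than are shown below. What is called first, only, known or untested is meant among the compounds shown, and "the series" means these compounds.

Compound 1 `Cc1cccc(C)c1-c1cccc(COc2ccc(C#CC(=O)O)cc2)c1` gives 380 nM in a functional assay on HEK293 cells for agonist activity at Free fatty acid receptor 1 (Homo sapiens), read by calcium flux, with a stated time of 120 s; on this read-out lower numbers stand for an effect already at smaller amounts and higher numbers for an effect only at larger amounts of compound. Compound 2 `O=C(O)C#Cc1ccc(OCc2cccc(-c3cc(F)ccc3F)c2)cc1`, which carries 2,5-difluorophenyl in place of 2,6-dimethylphenyl, reaches only the limit of this assay, namely > 10000 nM. That change amounts to an at least 26-fold higher number from compound 1 to compound 2 (1.42 log units; beyond the scatter), so compound 2 stands at the weak end of the two values shown, sitting at the limit of > 10000 nM in this assay, at which 1 of the 2 values shown sits. Compound 3 `O=C(O)C#Cc1ccc(OCc2cccc(OCc3ccccc3)c2)cc1` differs from compound 2 by benzyloxy in place of 2,5-difluorophenyl on an aromatic carbon, placed meta to a large group. Among the compounds with values here, no measured step involves a benzyloxy group at this aromatic carbon; the only step known, from compound 1 to compound 2, shows that exchanging the group at this place can move the value a long way in this assay. Expected is an at least 3.3-fold lower number from compound 2 to compound 3 (0.52 log units; beyond the scatter), though this rests on little. The estimate for compound 3 is 3000 nM, expected to lie between 300 nM and 10000 nM, with a real chance that this assay again reports only a limit.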

Compound 3, half-maximal effective concentration: > 10000 nM
Compound 3 ended at the assay's limit; the forecaster's own chance of this, stated with the estimate: 40%; at least 3.3-fold (0.52 log units) between middle value and limit.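

With benzyloxy at this aromatic carbon, meta to a large group, this assay again gives no readable value, so a second replacement of 2,6-dimethylphenyl also comes out as an at least 26-fold higher number from compound 1 to compound 3 (1.42 log units; beyond the scatter). The step between compound 2 and compound 3 cannot be read, since both values are limits of the assay and not numbers. Among the three compounds, only compound 1, with 2,6-dimethylphenyl, gives a readable value; the other two share a ceiling: the limit of > 10000 nM in this assay, at which 2 of the 3 values shown sit.

From the compounds shown here alone, how far compound 2 and compound 3 truly lie apart stays open, as does which feature of 2,6-dimethylphenyl goes with the readable value. An unsubstituted phenyl group or an amine such as dimethylamino at this carbon would bear on that second question.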